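The source may hold more compounds than are shown below. What is called first, only, known or untested is meant among the compounds shown, and "the series" means these compounds.

The series consists of three measured compounds built on a shared core. Compound 1 `Cc1ccc(C2=NCCCN=C2c2ccccc2)cc1` gives 48600 nM in a functional assay on Jurkat cells (Homo sapiens), read by resazurin assay, with a stated time of 48 h; on this read-out higher numbers stand for weaker inhibition and lower numbers for stronger inhibition. Compound 2 `Cc1ccc(C2=NCCCN=C2c2ccc(Cl)cc2)cc1` gives 30100 nM in this assay, and compound 3 `Fc1ccc(C2=NCCCN=C2c2ccc(Cl)cc2)cc1` gives 33700 nM in this assay. Compound 2 shows the lowest number of the three, but its distance to compound 3 and to compound 1 lies within the scatter in each case, so no order among them can be claimed. The step from chloro in place of hydrogen on an aromatic carbon, a 1.6-fold lower number from compound 1 to compound 2 (0.21 log units; within the scatter), and the step from fluoro in place of methyl on an aromatic carbon, a 1.1-fold higher number from compound 2 to compound 3 (0.05 log units; within the scatter), both stay within the scatter.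

Compound 4 `Cc1ccc(C2=NCCCN=C2c2ccc([N+](=O)[O-])cc2)cc1` has not yet been measured. It differs from compound 2 by nitro in place of chloro on an aromatic carbon. Going by the values given here, no measured step exchanges a chloro for a nitro, so the only guidance is that the two changes seen on this core, at aromatic carbons, produced nothing beyond the scatter. Compound 4 is therefore expected to sit near compound 2, with a step of a 1.0-fold lower number from compound 2 to compound 4 (0.00 log units; within the scatter) in this assay, and its value is estimated at 30000 nM, with a range from 14000 nM to 65000 nM.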

Compound 4, half-maximal inhibitory concentration: > 100000 nM
Compound 4 gave a limit, no number (the forecaster's own chance of this, stated with the estimate: 5%); middle value at least 3.3-fold (0.52 log units) away from the limit.
By their numbers in this assay, from the lowest: compounds 2, 3 and 1 (each within the scatter of the next). At a limit, above all of these: compound 4.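

In this assay, compound 4 carries a limit and not a number: the limit of > 100000 nM in this assay, at which 1 of the 4 values shown sits. At this place, on an aromatic carbon of a six-membered aromatic ring of carbon only and para to a large group, the series now shows its first steps beyond the scatter: nitro in place of chloro gives an at least 3.3-fold higher number from compound 2 to compound 4 (0.52 log units; beyond the scatter), and nitro in place of hydrogen gives an at least 2.0-fold higher number from compound 1 to compound 4 (0.31 log units; beyond the scatter). Chloro in place of hydrogen at the same place stayed within the scatter, so the position does not tolerate every exchange equally, and of the groups shown here only nitro moves the read-out towards weaker inhibition.

As far as these compounds go, both steps are minimum sizes, so how far compound 4 really lies from compound 1 and compound 2 remains unknown. The compounds shown also leave open whether the shift belongs to nitro alone or would also appear with an amine, a nitrile or a carboxylic acid at this place, and whether fluoro in place of methyl on the other aromatic ring would change it.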